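This account rests on a few compounds, and the source may have more. Where it says the series, first, only, none or still open, it means among the compounds named here.

Compound 2 `CC(=O)N1N=C(c2ccc(Cl)cc2)OC1c1ccc(Cl)c(Cl)c1` gives 627 nM in an assay on BTI cells for inhibition of Amine oxidase [flavin-containing] B (Homo sapiens), read by fluorescence and Amplex Red, with a stated time of 15 min (a lower number here means a stronger inhibitor, a higher number a weaker inhibitor), the highest of the three numbers. Compound 1 `CC(=O)N1N=C(c2ccc(Cl)cc2)O[C@@H]1c1ccc(Cl)c(Cl)c1` gives 204 nM; the change a 3.1-fold higher number from compound 1 to compound 2 (0.49 log units; beyond the scatter) goes with the fact that one of compounds 1 and 2 is drawn with a defined configuration and the other without, at the place where they differ. Compound 3 `CC(=O)N1N=C(c2ccc(Br)cc2)OC1c1ccc(Cl)c(Cl)c1` gives 67.7 nM, and the change a 9.3-fold lower number from compound 2 to compound 3 (0.97 log units; beyond the scatter) shows that the ring on the carbon with a double bond to nitrogen matters in this assay. Compound 4 `CC(=O)N1N=C(c2ccccc2C)OC1c1ccc(Cl)c(Cl)c1` differs from compound 2 in that place: 2-methylphenyl in place of 4-chlorophenyl on a carbon with a double bond to nitrogen. Among the measured compounds shown here, no measured step tests a methyl there or the loss of a halogen, so the bromo step only shows the place is sensitive. Compound 4 is expected at 1500 nM (range 400 nM to 6000 nM), a weakening estimated as a 2.4-fold higher number from compound 2 to compound 4 (0.38 log units; beyond the scatter).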

Compound 4, half-maximal inhibitory concentration: 2460 nM
Compound 4: the middle estimate sits 1.6-fold (0.21 log units) below what was measured; the measured number falls inside the stated range.
By their numbers in this assay, from the lowest: compound 3; then compound 1; then compound 2; then compound 4.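

The place is sensitive in both directions: 2-methylphenyl in place of 4-chlorophenyl weakens inhibition (a 3.9-fold higher number from compound 2 to compound 4 (0.59 log units; beyond the scatter)), where the bromo step had shown only a gain. Against 4-bromophenyl, the change is the largest step shown (a 36-fold higher number from compound 3 to compound 4 (1.56 log units; beyond the scatter)). Nothing available explains this loss.

Methyl placement and loss of the halogen change together here, so the compounds shown cannot separate the two. They also leave open how an unsubstituted phenyl, or a methoxy group or an amine on this ring, would behave.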